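The source may report more compounds than this note shows. Statements on the series, on what has been measured and on what is new or still open speak of the compounds shown alone.

Compound 1, `CC1(C)CC(=O)N(c2ccccc2C(=O)OCC2CCCN(CCCc3ccccc3)C2)C1=O`, gives 7500 nM.
Compound 2, `CCCCCCCCC1CC(=O)N(c2ccccc2C(=O)OCC2CCCN(CCCc3ccccc3)C2)C1=O`, gives 1300 nM.

Both numbers come from a functional assay with Neuronal acetylcholine receptor; alpha3/beta4 (Homo sapiens) as the target; a lower number here means a stronger inhibitor, a higher number a weaker inhibitor. Of the two, compound 2 has the lower number, and the gap up to compound 1 lies beyond the usual scatter of repeated measurements, so compound 2 stands as the stronger inhibitor of this pair.

Compound 3, `O=C(OCC1CCCN(CCCc2ccccc2)C1)c1ccccc1N1C(=O)CC(Cc2ccccc2)C1=O`, shares the core of compound 2 and differs from it in one place: phenyl in place of heptyl on a saturated chain carbon bound to a saturated ring carbon. Among the compounds with values here, no pair of measured compounds shows this same change, so the two values above are the only guide. Compound 1 and compound 2 together show that what sits on that saturated ring carbon can move the number by a clearly visible amount, but they do not show in which direction a phenyl ring would move it.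

The expectation is a modest rise in the number, a step from compound 2 to compound 3 of a 1.9-fold higher number from compound 2 to compound 3 (0.28 log units; within the scatter), which may not exceed the scatter. Compound 3 is therefore estimated at 2500 nM in this assay, with a likely range of 800 nM to 8000 nM.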

Compound 3, half-maximal inhibitory concentration: 1300 nM
Estimate against measurement, compound 3: 1.9-fold (0.28 log units) above; low and high end bracket the measured number.
By their numbers in this assay, from the lowest: compounds 2 and 3 (each within the scatter of the next); then compound 1.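

Putting phenyl in place of heptyl on a saturated chain carbon bound to a saturated ring carbon gives no change at the digits printed from compound 2 to compound 3 (within the scatter) in this assay. Cut one bond further out, the same difference reads octyl to benzyl, so an open chain of carbons and a group that carries an aromatic ring give matching values at this place, and this is the first view of a ring here: the earlier compounds had only open carbon groups on the shared core and could not speak to this swap. Nothing in the data shown accounts for the match between these two very different groups, so it stands as an observation without an explanation.

Within the data shown here, the match covers only two groups, both built from carbon and hydrogen alone, so it remains open whether an amine, a carboxylic acid or a hydroxyl group at the same place would give a similar number. Going by these compounds, it is equally open whether a phenyl ring carrying a fluorine or a methoxy group, or a much shorter chain such as ethyl, would keep the value of compound 3 in this assay.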